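This account rests on a few compounds, and the source may have more. Where it says the series, first, only, none or still open, it means among the compounds named here.

Compound 1 `COc1cc(Nc2nnc(Cl)c(Nc3cc(OC)c(OC)c(OC)c3)n2)cc(OC)c1OC` measured at 24300 nM so far
Compound 2 `CCOC(=O)c1ccc(Nc2nnc(Cl)c(Nc3cc(OC)c(OC)c(OC)c3)n2)cc1` measured at 53600 nM so far

Among the measured compounds shown here, both values come from a functional assay on MGC-803 cells (Homo sapiens) for inhibition, read by MTT assay, with a stated time of 48 h (on this read-out higher numbers stand for weaker inhibition and lower numbers for stronger inhibition), and are the only numbers available for the series. Compound 2 at 53600 nM holds the higher of the two numbers, and compound 1 at 24300 nM lies below it by a gap beyond the usual scatter.

Compound 3 `COc1cc(Nc2nc(Nc3ccc(Br)cc3)nnc2Cl)cc(OC)c1OC` has not yet been measured. It carries bromo in place of ethoxycarbonyl on an aromatic carbon, para to a large group, and the rest of the structure matches compound 2. The count for this change is bromo in place of ethoxycarbonyl on an aromatic carbon and it is the only difference.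

For the measured compounds named here, no measured pair shows this exchange, so the only guide is the span from compound 1 at 24300 nM to compound 2 at 53600 nM in this assay and the expectation is loose. A modest move toward a lower number is expected, and the estimate is a 2.1-fold lower number from compound 2 to compound 3 (0.31 log units; beyond the scatter) in this assay with no large change foreseen. The estimated value for compound 3 is 26000 nM with an expected range from 9000 nM to 70000 nM when measured.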

Compound 3, half-maximal inhibitory concentration: 11400 nM
Estimate against measurement, compound 3: 2.3-fold (0.36 log units) above, and the stated range covers the measured number.
By their numbers in this assay, from the lowest: compound 3; then compound 1; then compound 2.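

In this assay, among the compounds shown here, the aromatic carbon para to a large group proves sensitive to its substituent: bromo in place of ethoxycarbonyl gives a 4.7-fold lower number from compound 2 to compound 3 (0.67 log units; beyond the scatter), the only single-place step available and one beyond the usual scatter. The exchange removes 5 heavy atoms, including 2 hydrogen-bond acceptors, and puts a single bromine with no hydrogen-bond acceptors in their place, so ethoxycarbonyl is not required at this position for inhibition to be read, and compound 3 gives 11400 nM. No measurement bears on what lies behind this step.

Going by these compounds, whether the lower number belongs to bromo itself or simply follows the loss of ethoxycarbonyl stays open, and chloro, methyl or a carboxylic acid on the same aromatic carbon would help separate the two. Also open, on these data alone, is how the series responds elsewhere, for instance with an amine in place of the chloro on the shared core, and whether this step keeps its size on such a changed core.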